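A Methyl Added to the Aromatic Ring of Compound 3

This account rests on a few compounds, and the source may have more. Where it says the series, first, only, none or still open, it means among the compounds named here.

Of the compounds shown here, three sharing one core have been measured in an assay on CHO cells for displacement of a labelled ligand from histamine receptor H3 (Macaca mulatta); a higher number here means a weaker inhibitor, a lower number a stronger inhibitor. Compound 1 `CC(=O)N1CCCC1C(=O)Nc1ccc(N2CCC(N3CCCC3C)C2)c(C)c1` gives 44.9 nM and compound 2 `Cc1cc(NC(=O)C2C(C)(C)C2(C)C)ccc1N1CCC(N2CCCC2C)C1` gives 65.5 nM, while compound 3 `CC1CCCN1C1CCN(c2ccc(NC(=O)C3CCCO3)cc2)C1` gives 8.7 nM, the lowest of the three numbers; its nearest neighbour is compound 1 and its furthest is compound 2, and both gaps lie beyond the scatter. Within the data shown here, the single step between measured neighbours, a 1.5-fold higher number from compound 1 to compound 2 (0.16 log units; within the scatter), lies within the scatter and concerns the group on the carbonyl carbon, not the aromatic ring. Compound 4 `Cc1cc(NC(=O)C2CCCO2)ccc1N1CCC(N2CCCC2C)C1` differs from compound 3 by methyl in place of hydrogen on an aromatic carbon. Among the measured compounds shown here, no measured pair isolates this change: compounds 1 and 2 both already carry the methyl, and neither has an unmethylated partner, so the only measured step touches a different part of the molecule. For the measured compounds named here, with no direct precedent, the expected step in this assay, a 1.4-fold higher number from compound 3 to compound 4 (0.14 log units; within the scatter), is one that stays within the scatter, in either direction. Compound 4 is therefore estimated at 12 nM, with a range from 5 nM to 30 nM.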

Compound 4, inhibition constant: 17 nM
The estimate for compound 4 lay 1.4-fold (0.15 log units) below the measured number; the range from low to high includes it.
By their numbers in this assay, from the lowest: compounds 3 and 4 (each within the scatter of the next); then compounds 1 and 2 (each within the scatter of the next).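

In this assay, among these compounds, the methyl on this aromatic carbon, ortho to a large group, can now be read on its own: the pair gives a 2.0-fold higher number from compound 3 to compound 4 (0.29 log units; within the scatter) and is the only measured pair that isolates this change. With the methyl present on all three compounds, the group on the carbonyl carbon can also be compared: oxolan-2-yl in place of 2,2,3,3-tetramethylcyclopropyl gives a 3.9-fold lower number from compound 2 to compound 4 (0.59 log units; beyond the scatter) and in place of 1-acetylpyrrolidin-2-yl gives a 2.6-fold lower number from compound 1 to compound 4 (0.42 log units; beyond the scatter), so that group still separates these compounds. Nothing available explains either result.

From the compounds shown here alone, it remains open whether an ethyl, a methoxy or a chlorine on this aromatic carbon would behave as the methyl does. Going by these compounds, it is also open whether the methyl gives a similar step with the other two groups on the carbonyl carbon.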